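Dropping the Phenoxy Oxygen: Compound 2 to Compound 4

The source may hold more compounds than are shown below. What is called first, only, known or untested is meant among the compounds shown, and "the series" means these compounds.

Three analogues sharing one core were measured in a functional assay on CHO cells for agonist activity at Free fatty acid receptor 1 (Homo sapiens), read by FLIPR and calcium flux, tested at 1 uM; on this read-out lower numbers stand for an effect already at smaller amounts and higher numbers for an effect only at larger amounts of compound. Compound 1 `O=C(O)CCc1ccc(NC(=O)c2nnc(COc3ccc(F)cc3)s2)cc1` gives 5390 nM, compound 2 `O=C(O)CCc1ccc(NC(=O)c2nnc(COc3cccc(Cl)c3)s2)cc1` gives 1570 nM, and compound 3 `Cc1ccccc1OCc1nnc(C(=O)Nc2ccc(CCC(=O)O)cc2)s1` gives 1520 nM. Compound 2 thus stands second highest of the three numbers: a 3.4-fold lower number from compound 1 to compound 2 (0.54 log units; beyond the scatter), a 3.5-fold lower number from compound 1 to compound 3 (0.55 log units; beyond the scatter), while the step to compound 3 lies within the scatter, a 1.0-fold lower number from compound 2 to compound 3 (0.01 log units; within the scatter). Compound 4 `O=C(O)CCc1ccc(NC(=O)c2nnc(Cc3ccccc3)s2)cc1` differs from compound 2 by phenyl in place of 3-chlorophenoxy on a saturated chain carbon bound to an aromatic carbon. Every measured step changed the ring on the oxygen yet kept that oxygen, so none bears directly on removing it; the steps that exist were modest in size. A small movement in either direction in this assay is therefore expected, a 1.6-fold higher number from compound 2 to compound 4 (0.20 log units; within the scatter). Compound 4 is estimated at 2500 nM, within 800 nM to 8000 nM.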

Compound 4, half-maximal effective concentration: 3670 nM
For compound 4 the middle estimate is 1.5-fold (0.17 log units) below the measured one, within the range that was stated.
By their numbers in this assay, from the lowest: compounds 3 and 2 (each within the scatter of the next); then compounds 4 and 1 (each within the scatter of the next).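

In this assay, going by these compounds alone, the first steps that remove the oxygen at this position give a higher number from two of the rings: 3-chlorophenoxy (a 2.3-fold higher number from compound 2 to compound 4 (0.37 log units; beyond the scatter)) and 2-methylphenoxy (a 2.4-fold higher number from compound 3 to compound 4 (0.38 log units; beyond the scatter)). The same kind of change from 4-fluorophenoxy stays within the scatter (a 1.5-fold lower number from compound 1 to compound 4 (0.17 log units; within the scatter)), so the outcome differs with the group replaced. No measurement on hand gives a cause for these steps.

Each step removes the oxygen and the ring substituent together, so their shares cannot be separated. As far as these compounds go, how an unsubstituted phenoxy or an amine in place of the oxygen would read remains open.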